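Adding a fluoro to compound 2: what to expect

The source may report more compounds than this note shows. Statements on the series, on what has been measured and on what is new or still open speak of the compounds shown alone.

- Compound 1 (`CC(=O)Nc1ccc2oc(-c3ccccc3F)c(O)c(=O)c2c1`) gives 171000 nM
- Compound 2 (`Nc1ccc2oc(-c3ccccc3)c(O)c(=O)c2c1`) gives 217000 nM
- Compound 3 (`COc1cccc(-c2oc3ccc(N)cc3c(=O)c2O)c1`) gives 40800 nM

These numbers come from an ADME assay on MT4 cells (Homo sapiens) for cytotoxicity, read by MTT assay, with a stated time of 4 days; on this read-out lower numbers stand for higher toxicity in this test and higher numbers for lower toxicity in this test. Compound 2 (217000 nM) lies within the scatter of compound 1 (171000 nM), at the less toxic end of this small set. Compound 4 (`Nc1ccc2oc(-c3ccccc3F)c(O)c(=O)c2c1`) has fluoro in place of hydrogen on an aromatic carbon. Within the data shown here, the only measured single change used methoxy, a different group, and was modest (a 5.3-fold lower number from compound 2 to compound 3 (0.73 log units; beyond the scatter)). Compound 1 (171000 nM) holds the same fluoro plus one further change, yet stays within the scatter of compound 2. So no shift beyond the scatter is expected, and the expected step is small (a 1.3-fold lower number from compound 2 to compound 4 (0.11 log units; within the scatter)). Compound 4 is estimated at 170000 nM (70000 nM to 350000 nM).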

Compound 4, half-maximal cytotoxic concentration: 44500 nM
Compound 4: the middle estimate sits 3.8-fold (0.58 log units) above what was measured; measured number below the stated range.
By their numbers in this assay, from the lowest: compounds 3 and 4 (each within the scatter of the next); then compounds 1 and 2 (each within the scatter of the next).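

In this assay a single fluoro in place of hydrogen, ortho to a large group, gives a 4.9-fold lower number from compound 2 to compound 4 (0.69 log units; beyond the scatter) and so makes the compound more toxic in this test, showing that even this small change counts at this position. With the fluoro present, the acetyl on the nitrogen matters too: replacing it with hydrogen gives a 3.8-fold lower number from compound 1 to compound 4 (0.58 log units; beyond the scatter) on the same fluoro-bearing core. No measurement shown explains this increase in toxicity. From the compounds shown here alone, whether a chloro or a methyl at this position would act like the fluoro remains open.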